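The compounds below may be only part of what the source reports. "The series", "measured", "known", "first", "only" and "open" are said of these compounds alone.

Of the compounds shown here, three that share one core have been measured in a functional assay on Z-138 cells (Homo sapiens) for antiproliferative activity, with a stated time of 72 h; on this read-out lower numbers stand for stronger inhibition and higher numbers for weaker inhibition. Compound 1 `Nc1ncnn2c([C@@H]3O[C@H](CO)[C@@H](O)[C@H]3O)cc(C#CC3CC3)c12` carries a 2-cyclopropylethynyl group on an aromatic carbon of the core, and compound 1 gives 20 nM. Compound 2 `Nc1ncnn2c([C@@H]3O[C@H](CO)[C@@H](O)[C@H]3O)cc(-c3ccccc3F)c12` carries a 2-fluorophenyl group in the same place, and in this assay compound 2 gives 95300 nM. Compound 3 `COc1ccc(-c2cc([C@@H]3O[C@H](CO)[C@@H](O)[C@H]3O)n3ncnc(N)c23)cc1` carries a 4-methoxyphenyl group there, and compound 3 gives 62600 nM. Among these three numbers compound 3 stands second highest: the step to its nearest neighbour lies within the scatter, a 1.5-fold lower number from compound 2 to compound 3 (0.18 log units; within the scatter), while at the far end lies a 3100-fold higher number from compound 1 to compound 3 (3.50 log units; beyond the scatter). Both aromatic replacements of the 2-cyclopropylethynyl group brought large increases, a 4800-fold higher number from compound 1 to compound 2 (3.68 log units; beyond the scatter) and a 3100-fold higher number from compound 1 to compound 3 (3.50 log units; beyond the scatter).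

Compound 4 `Nc1ncnn2c([C@@H]3O[C@H](CO)[C@@H](O)[C@H]3O)cc(-c3ccccc3Cl)c12` has not yet been measured. It differs from compound 3 in one place: 2-chlorophenyl in place of 4-methoxyphenyl on an aromatic carbon. The step that bears most directly on this change is the earlier swap of one six-membered aromatic ring of carbon for another, which gave a 1.5-fold lower number from compound 2 to compound 3 (0.18 log units; within the scatter). Going by the values given here, the two large steps away from compound 1 show only that either aromatic ring is far weaker than the 2-cyclopropylethynyl group, and say nothing about how one aromatic ring compares with another. A third aromatic ring is therefore expected to land near the other two, with no step beyond the scatter. Compound 4 is estimated at 80000 nM, in the range 20000 nM to 300000 nM. That estimate means an expected 1.3-fold higher number from compound 3 to compound 4 (0.11 log units; within the scatter).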

Compound 4, half-maximal inhibitory concentration: 76100 nM
Beside the measured number, compound 4's estimate is 1.1-fold (0.02 log units) above it, within the range that was stated.
By their numbers in this assay, from the lowest: compound 1; then compounds 3, 4 and 2 (each within the scatter of the next).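

In this assay, a third aromatic ring at this position reads like the first two: 2-chlorophenyl in place of 4-methoxyphenyl gave a 1.2-fold higher number from compound 3 to compound 4 (0.08 log units; within the scatter), and chloro in place of fluoro on the same ring gave a 1.3-fold lower number from compound 2 to compound 4 (0.10 log units; within the scatter), so neither change moved the number beyond the usual scatter. The large distance from the 2-cyclopropylethynyl group also holds for this new ring, with a 3800-fold higher number from compound 1 to compound 4 (3.58 log units; beyond the scatter), which makes it a gap seen with 2-fluorophenyl, 4-methoxyphenyl and 2-chlorophenyl alike rather than a feature of a single ring. No measurement on hand explains why these rings read alike or why they lie so far from compound 1.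

The compounds shown leave open which part of the 2-cyclopropylethynyl group goes with the low number, a question that a plain ethynyl group, an alkyne with a longer chain or a cyclopropyl group placed directly on the core could help to settle. On these data alone, it also remains open whether any aromatic ring can come close to compound 1, for example a phenyl ring carrying an amine or a carboxylic acid.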